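Compound 4 Against a Background of Three Limits

A few compounds are considered here, and "the series" means these few. Any claim that something is new, unique, unknown or untested is made for them only; others in the source may bear on it.

Measured compounds in an assay on isolated protein for inhibition of DNA nucleotidylexotransferase (Homo sapiens), read by scintillation counting, with a stated time of 10 min; on this read-out higher numbers stand for weaker inhibition and lower numbers for stronger inhibition:
- Compound 1, `C/C=C/Cn1cc(/C=C/C(=O)CC(=O)C(=O)OCC)c2ccccc21`, gives only the assay limit > 40 uM.
- Compound 2, `CCOC(=O)C(=O)CC(=O)/C=C/c1cn(Cc2ccc(F)cc2)c2ccccc12`, gives only the assay limit > 40 uM.
- Compound 3, `CCOC(=O)C(=O)CC(=O)/C=C/c1cn(Cc2ccc(OC)cc2)c2ccccc12`, gives only the assay limit > 40 uM.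

Compound 1 therefore stands at a limit of this assay, not at a measured number, and the same is true of the other two compounds, all three sitting at the limit of > 40 uM in this assay, at which 3 of the 3 values shown sit. Because of that, the step that the two limits leave unreadable from compound 1 to compound 2 cannot be read, and neither can a step that the two limits leave unreadable from compound 1 to compound 3 nor a step that the two limits leave unreadable from compound 2 to compound 3: the structures change at the saturated chain carbon bound to the aromatic nitrogen or on the aromatic carbon, but the numbers give no size for any of these changes.

Compound 4, `CCOC(=O)C(=O)CC(=O)/C=C/c1cn(CC(=O)N2CCOCC2)c2ccccc12`, changes the same position as compounds 2 and 3 did. Compared with compound 1 the difference is (morpholin-4-yl)carbonyl in place of prop-1-en-1-yl on a saturated chain carbon bound to an aromatic nitrogen. Within the data shown here, no measured step bears a readable size on this change, so no shift beyond the scatter can be expected in either direction, and compound 4 is expected most likely to return a limit again. The estimated step is a step that the limit leaves unreadable from compound 1 to compound 4. The estimate for compound 4 in this assay is 50 uM, with a range from 20 uM to 200 uM.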

Compound 4, concentration for 50% inhibition: > 40 uM
Compound 4: only a limit was reported; the forecaster's own chance of this, stated with the estimate: 85%; the middle value lies beyond the limit too.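

Compound 4 gives > 40 uM, which is a limit and not a number. No step from compound 1, compound 2 or compound 3 to compound 4 can be read: the limit of > 40 uM in this assay, at which 4 of the 4 values shown sit.

The compounds shown leave open whether any group at this place gives a measurable value in this assay.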